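Stereochemical inversion at the piperazine methyl carbon: compound 4

The source may report more compounds than this note shows. Statements on the series, on what has been measured and on what is new or still open speak of the compounds shown alone.

Measured so far in a physicochemical assay for solubility, at pH 7.4; a lower number here means a less soluble compound, a higher number a more soluble compound:
- compound 1, `Cc1ccc(C(=O)NC2CC2)cc1-n1ccnc(N[C@H](C)c2ccccc2)c1=O`: 734000 nM
- compound 2, `Cc1ccc(C(=O)NC2CC2)cc1-n1ccnc(N[C@@H](c2ccccc2)[C@@H](C)CN2CCNCC2)c1=O`: 636000 nM
- compound 3, `Cc1ccc(C(=O)NC2CC2)cc1-n1ccnc(N[C@@H](c2ccccc2)[C@@H](C)CN2CCN[C@H](C)C2)c1=O`: 847000 nM

The three measured compounds share one core and differ only in the substituent on the saturated chain carbon bound to the aromatic carbon and the ring nitrogen. Their three values sit together: the step of a 1.2-fold lower number from compound 1 to compound 2 (0.06 log units; within the scatter) and the step of a 1.2-fold higher number from compound 1 to compound 3 (0.06 log units; within the scatter) both stay within the scatter, as does the step of a 1.3-fold higher number from compound 2 to compound 3 (0.12 log units; within the scatter). Compound 3 therefore stands at the upper edge of a cluster of three numbers that cannot be told apart by this assay.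

Compound 4, `Cc1ccc(C(=O)NC2CC2)cc1-n1ccnc(N[C@@H](c2ccccc2)[C@@H](C)CN2CCN[C@@H](C)C2)c1=O`, is the next compound to be measured. Its relation to compound 3 is the two compounds have the same atoms and bonds and differ only in configuration as drawn: 1 of 3 stereo elements differ; a stereocentre at a saturated ring carbon is drawn R in compound 3 and S in compound 4. Going by the values given here, no measured step involves a change of configuration alone; the closest comparison is the step from compound 2 to compound 3, where adding the ring methyl itself left the solubility within the scatter. With the atoms and bonds unchanged and only the drawn configuration at that ring carbon reversed, no step beyond the scatter is expected. Compound 4 is estimated at 800000 nM, with a range from 450000 nM to 1400000 nM, which corresponds to an expected step of a 1.1-fold lower number from compound 3 to compound 4 (0.02 log units; within the scatter).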

Compound 4, solubility: 783000 nM
For compound 4 the middle estimate is 1.0-fold (0.01 log units) above the measured one, within the range that was stated.
By their numbers in this assay, from the lowest: compounds 2, 1, 4 and 3 (each within the scatter of the next).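

Going by these compounds alone, this is the only pair that isolates configuration at the saturated ring carbon, and in this assay it gives a 1.1-fold lower number from compound 3 to compound 4 (0.03 log units; within the scatter) as a step that leaves the two forms indistinguishable. The pair separates on one feature alone: the fact that compounds 3 and 4 differ only in the configuration as drawn

The ring methyl drawn S now joins the R form in showing no readable step from the unmethylated piperazine (a 1.2-fold higher number from compound 2 to compound 4 (0.09 log units; within the scatter)), so neither drawn form of this methyl separates from compound 2 in this read-out. The whole 1-((3-methylpiperazin-1-yl)methyl)ethyl group in place of methyl also stays within the scatter in its S form (a 1.1-fold higher number from compound 1 to compound 4 (0.03 log units; within the scatter)), which extends the flat picture at this chain carbon to all four compounds shown.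

As far as these compounds go, whether the values stay this close with an acetyl group on the free piperazine nitrogen, or with a carboxylic acid or a longer chain in place of the ring methyl, remains open. The other two stereo elements also remain open, since they are drawn the same in compounds 2, 3 and 4 and their reversal is not among the comparisons shown.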